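This account rests on a few compounds, and the source may have more. Where it says the series, first, only, none or still open, it means among the compounds named here.

Measured so far in a functional assay on cells (Lymphocyte); a higher number here means a weaker inhibitor, a lower number a stronger inhibitor: compound 1, `O=C(COc1ccc(Cl)cc1)N1CCN(c2nc(-c3ccccc3)nc3sc(F)cc23)CC1`, gives > 10000 nM. For compound 1 this value is a limit of the assay and not a number. Compound 2, `Nc1nc(N2CCN(C(=O)COc3ccc(Cl)cc3)CC2)c2cc(F)sc2n1`, gives 700 nM. Within the data shown here, compound 2 gives the only number in this assay; the one further value in the set is a limit. Among the measured compounds shown here, the single step so far, an at least 14-fold lower number from compound 1 to compound 2 (1.15 log units; beyond the scatter), rests on the limit of > 10000 nM in this assay, at which 1 of the 2 values shown sits, and so is known only as a lower bound.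

Compound 3, `Nc1nc(N2CCN(C(=O)c3cccnc3)CC2)c2cc(F)sc2n1`, differs from compound 2 in one place: pyridin-3-yl in place of (4-chlorophenoxy)methyl on a carbonyl carbon. For the measured compounds named here, the measured step concerns a change on an aromatic carbon of the shared core, not the carbonyl carbon, so no measured step bears directly on this change. The direction of the change at the carbonyl carbon is therefore unsupported by the numbers in hand, and the estimate has to be wide.

Compound 3 is expected to give 2000 nM in this assay, within 500 nM to 10000 nM. The estimated step of a 2.9-fold higher number from compound 2 to compound 3 (0.46 log units; beyond the scatter) is a modest weakening, with a real chance that only a limit is reported.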

Compound 3, half-maximal inhibitory concentration: > 10000 nM
Compound 3: a limit, no number (the forecaster's own chance of this, stated with the estimate: 30%); middle value at least 5.0-fold (0.69 log units) from the limit.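

The earlier compounds shown here changed only a group on an aromatic carbon of the shared core, whereas this pair shows that the group on the carbonyl carbon also has a large bearing on the read-out in this assay. Pyridin-3-yl in place of (4-chlorophenoxy)methyl gives an at least 14-fold higher number from compound 2 to compound 3 (1.15 log units; beyond the scatter). The value of compound 3 is a limit and not a number, so only a lower bound on the size of this step is known: the limit of > 10000 nM in this assay, at which 2 of the 3 values shown sit.

The amino group on the shared core is present in both compounds, so it is not sufficient on its own to give the number of compound 2, 700 nM.

The exchange alters the chlorine, the ether oxygen, the methylene chain and the ring in one move, so this pair cannot show which of these parts matters. On these data alone, it remains open whether a plain phenoxymethyl group, a 4-fluorophenoxymethyl group or a pyridin-3-yloxymethyl group on the carbonyl carbon would give a number rather than a limit in this assay.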